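This account rests on a few compounds, and the source may have more. Where it says the series, first, only, none or still open, it means among the compounds named here.

The measured compounds:
compound 1, `O=C(O)COCCCCC1=CCC[C@@H]1CNS(=O)(=O)c1ccc(F)cc1`: 200 nM
compound 2, `O=C(O)COCCCCC1=CCC[C@@H]1NS(=O)(=O)c1ccc(Cl)c(Cl)c1`: 1900 nM
compound 3, `O=C(O)CC/C=C\CC1=CCC[C@@H]1NS(=O)(=O)c1ccc(Cl)c(Cl)c1`: 1900 nM

All three were read in a functional assay on a cell-free system (plasma) for inhibition of thromboxane A2 receptor (Homo sapiens), read by turbidimetry; a higher number here means a weaker inhibitor, a lower number a stronger inhibitor. Compound 1 gives the lowest of the three numbers, and both other compounds lie beyond the scatter from it. How the core of compound 1 differs from the core of compound 2 is not broken down here. Compound 2 and compound 3 differ in one place: 4-carboxybut-1-en-1-yl in place of 3-(carboxymethoxy)propyl on a saturated chain carbon bound to a double-bonded ring carbon. That change made no change at the digits printed from compound 2 to compound 3 (within the scatter). Compound 4, `O=C(O)CC/C=C\CC1=CCC[C@@H]1CNS(=O)(=O)c1ccc(F)cc1`, is not yet measured; it differs from compound 1 by the same change, (4-carboxybut-1-en-1-yl in place of 3-(carboxymethoxy)propyl on a saturated chain carbon bound to a double-bonded ring carbon), and the place is described in the same words. Because the earlier step was no change at the digits printed from compound 2 to compound 3 (within the scatter), the step expected for compound 4 is no change at the digits printed from compound 1 to compound 4 (within the scatter). Compound 4 is therefore estimated at 200 nM, expected to fall between 100 nM and 450 nM.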

Compound 4, half-maximal inhibitory concentration: 600 nM
For compound 4 the middle estimate is 3.0-fold (0.48 log units) below the measured one; the whole stated range lies below it.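

Putting 4-carboxybut-1-en-1-yl in place of 3-(carboxymethoxy)propyl gave a 3.0-fold higher number from compound 1 to compound 4 (0.48 log units; beyond the scatter) in this assay. Among the compounds shown here, the change therefore did not carry over unaltered from one core to the other: the same change on two cores in this assay, no change at the digits printed (within the scatter) from compound 2 to compound 3 and a 3.0-fold higher number (0.48 log units; beyond the scatter) from compound 1 to compound 4, 3.0-fold (0.48 log units) apart, beyond the scatter of two such steps With only two cores, this shows that the size of the step depended on the core in these compounds, but it does not show which feature of the cores is responsible or how the change would behave on any further core.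

The compounds shown leave open how a tetrazole in place of the carboxylic acid, or a longer chain carrying that acid, would read in this assay.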